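The compounds below may be only part of what the source reports. "The series", "measured", "known", "first", "only" and "open" are said of these compounds alone.

In a physicochemical assay for solubility, read by nephelometry, measured as kinetic solubility, at pH 2.0 (a higher number here means a more soluble compound, a lower number a less soluble compound), three compounds from this series have been measured so far. Compound 1 `CCOC(=O)C1=C(C)N/C(=C/c2cc(C)n(-c3cccnc3)c2C)C1=O` gives > 50 ug/mL in this assay, which is a limit of the measurement rather than a number. Compound 2 `CCOC(=O)C1=C(C)N/C(=C/c2cc(C)n(Cc3ccc(C(F)(F)F)cc3)c2C)C1=O` gives 1.6 ug/mL in this assay. Compound 3 `CC1=C(C(=O)OC(C)(C)C)C(=O)/C(=C\c2cc(C)n(-c3ccccc3C(F)(F)F)c2C)N1` gives 3.1 ug/mL in this assay; this is the larger of the two numbers, but the gap to compound 2 lies within the usual scatter of repeated measurements, so the two cannot be ordered. Compound 1 stands apart from both only as a limit.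

The next compound, compound 4 `CC1=C(C(=O)OCc2ccccc2)C(=O)/C(=C\c2cc(C)n(-c3ccccc3C(F)(F)F)c2C)N1`, differs from compound 3 in a single place: benzyl in place of tert-butyl on an oxygen next to a carbonyl group, which may also be read as tert-butoxycarbonyl to benzyloxycarbonyl. Among the measured compounds shown here, no pair of measured compounds shows this change, so its effect in this assay is not yet known from the data. The expectation for the step from compound 3 to compound 4 is modest, a 1.6-fold lower number from compound 3 to compound 4 (0.19 log units; within the scatter), most likely a small decrease or none beyond the scatter. Compound 4 is therefore estimated at 2 ug/mL in this assay, between 0.7 ug/mL and 6 ug/mL.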

Compound 4, solubility: 1.6 ug/mL
Estimate against measurement, compound 4: 1.3-fold (0.10 log units) above; low and high end bracket the measured number.
By their numbers in this assay, from the lowest: compounds 2, 4 and 3 (each within the scatter of the next). At a limit, above all of these: compound 1.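

Among the compounds shown here, this is the first step read at this position: in this assay, benzyl in place of tert-butyl on an oxygen next to a carbonyl group gives a 1.9-fold lower number from compound 3 to compound 4 (0.29 log units; within the scatter), so the two compounds cannot be ordered. In this one pair, the position takes benzyl, with its six-membered aromatic ring of carbon only, in place of tert-butyl without a step beyond the scatter. Nothing measured here gives a cause for this step.

Going by these compounds, both groups in this step are carbon only, so it remains open how this position would read with a chain ending in an amine or a carboxylic acid. Also open, on these data alone, is whether the same change would give a similar step on the core of compound 2, since the step rests on one pair alone.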